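The compounds below may be only part of what the source reports. "The series", "measured", "known", "first", "only" and "open" are said of these compounds alone.

Compound 2 `Cc1ccccc1C#Cc1ccc(OCC(=O)O)cc1` gives the highest number of the two compounds tested in an in vitro functional assay on 1321-N1 cells for agonist activity at Free fatty acid receptor 1 (Homo sapiens), read by fluorescence (on this read-out higher numbers stand for an effect only at larger amounts of compound and lower numbers for an effect already at smaller amounts), with 3720 nM. Compound 1 `Cc1cccc(C#Cc2ccc(OCC(=O)O)cc2)c1` gives a lower number, 513 nM, a gap beyond the scatter of this assay. Compound 3 `O=C(O)COc1ccc(C#Cc2ccccc2)cc1` has not yet been measured. It differs from compound 2 in one place: hydrogen in place of methyl on an aromatic carbon. Going by the values given here, no step between measured compounds covers this change, so the expectation rests on the two values alone. A move toward a lower number, beyond the scatter, is expected, namely a 4.1-fold lower number from compound 2 to compound 3 (0.62 log units; beyond the scatter). Compound 3 is estimated at 900 nM, within 300 nM to 3000 nM.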

Compound 3, half-maximal effective concentration: 1260 nM
Compound 3: the middle estimate sits 1.4-fold (0.15 log units) below what was measured; low and high end bracket the measured number.
By their numbers in this assay, from the lowest: compound 1; then compound 3; then compound 2.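

In this assay the same exchange of methyl for hydrogen runs in opposite directions, with a 3.0-fold lower number from compound 2 to compound 3 (0.47 log units; beyond the scatter) when the methyl leaves the carbon ortho to a large group, but a 2.5-fold higher number from compound 1 to compound 3 (0.39 log units; beyond the scatter) when it leaves the carbon it holds in compound 1. Among these three compounds, the place of the methyl on this ring therefore decides the direction of the change. No measurement offered here explains this reversal. On these data alone, it remains open whether chlorine, methoxy or trifluoromethyl at either place would follow the methyl. As far as these compounds go, whether an ethyl group would do the same is equally open.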